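This account rests on a few compounds, and the source may have more. Where it says the series, first, only, none or still open, it means among the compounds named here.

Measured compounds:
Compound 2, `Oc1ccc(-c2cc(-c3cccc(Cl)c3)nc(-c3cccs3)c2)cc1`, gives 5350 nM in a functional assay on T47D cells (Homo sapiens) for cytotoxicity, read by CCK-8 assay and cell counting, with a stated time of 2 days; a higher number here means a weaker inhibitor, a lower number a stronger inhibitor.
Compound 3, `Oc1ccc(-c2cc(-c3cccnc3)nc(-c3cccc(Cl)c3)c2)cc1`, gives 25700 nM in this assay.
Compound 1, `Oc1cccc(-c2cc(-c3cccnc3)nc(-c3ccccc3Cl)c2)c1`, gives "not determined" (no result reported) in this assay.

Compound 4, `Oc1cccc(-c2cc(-c3cccs3)nc(-c3ccccc3Cl)c2)c1`, has not yet been measured. It differs from compound 1 by thiophen-2-yl in place of pyridin-3-yl on an aromatic carbon. The same kind of change links the two measured compounds, (thiophen-2-yl in place of pyridin-3-yl on an aromatic carbon), and there it made a 4.8-fold lower number from compound 3 to compound 2 (0.68 log units; beyond the scatter). The two changes are not the same: in the measured pair the place is meta to a 3-chlorophenyl group and meta to a 4-hydroxyphenyl group, whereas in the new pair it is meta to a 2-chlorophenyl group and meta to a 3-hydroxyphenyl group. The difference between the core of compound 1 and the core of compound 3 is not broken down here.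

For compound 1 the outcome is "not determined" (no result reported); the expectation for compound 4 thus cannot be set beside a starting value and rests on compound 2 alone, which carries the entering group and gives 5350 nM. Compound 4 is therefore expected to land near 6000 nM, within a wide range from 1200 nM to 30000 nM.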

Compound 4, half-maximal inhibitory concentration: 3990 nM
The estimate for compound 4 lay 1.5-fold (0.18 log units) above the measured number, within the range that was stated.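

Going by these compounds alone, with compound 1 at "not determined" (no result reported) in this assay, no step from compound 1 to compound 4 can be read. The compounds shown leave open whether thiophen-2-yl in place of pyridin-3-yl acts on the core of compound 1 as it did in a 4.8-fold lower number from compound 3 to compound 2 (0.68 log units; beyond the scatter). No other data here bear on this result.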